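Thiourea cytotoxicity in hamster cells: from furan to phenyl

The compounds below may be only part of what the source reports. "The series", "measured", "known", "first", "only" and "open" are said of these compounds alone.

Measured compounds and their values in an ADME assay on BHK cells (Mesocricetus auratus) for cytotoxicity, read by MTT assay, with a stated time of 96 h; a higher number here means that more compound is tolerated, a lower number that less compound is tolerated:
- compound 1 `FC(F)(F)c1cccc(NC(=S)Nc2cccc(Br)c2)c1` gives 10000 nM
- compound 2 `CCOC(=O)c1ccc(NC(=S)Nc2cccc(C(F)(F)F)c2)cc1` gives 50000 nM
- compound 3 `FC(F)(F)c1cccc(NC(=S)NCc2ccco2)c1` gives 48000 nM

All three share a thiourea core carrying a trifluoromethyl-substituted phenyl on one nitrogen; they differ only in what sits on the other nitrogen. Among the three numbers, compound 3 stands second highest, close to compound 2 (the two are within the scatter of this assay) and well above compound 1, which is the lowest.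

The next compound, compound 4 `FC(F)(F)c1cccc(NC(=S)Nc2ccccc2)c1`, has not been measured yet. It arises from compound 3 by one change: phenyl in place of (furan-2-yl)methyl on an amide-type nitrogen.

Within the data shown here, only one measured step bears on this change: a 4.8-fold higher number from compound 1 to compound 3 (0.68 log units; beyond the scatter), in which an aromatic six-membered ring was replaced by the furan-bearing chain. The new change runs the other way, bringing back a six-membered carbon ring, though without the bromine of compound 1. It is therefore expected that part of that earlier rise is undone, giving a modest step downward, a 2.4-fold lower number from compound 3 to compound 4 (0.38 log units; beyond the scatter).

For compound 4 in this assay, the expected value is 20000 nM, with a range from 8000 nM to 50000 nM.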

Compound 4, half-maximal cytotoxic concentration: 41000 nM
Estimate against measurement, compound 4: 2.1-fold (0.31 log units) below; measured number inside the range.
By their numbers in this assay, from the lowest: compound 1; then compounds 4, 3 and 2 (each within the scatter of the next).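

In this assay, putting phenyl in place of (furan-2-yl)methyl on the amide-type nitrogen yields a 1.2-fold lower number from compound 3 to compound 4 (0.07 log units; within the scatter), so a plain six-membered aromatic ring of carbon only is tolerated here about as well as the furan-bearing group, and a six-membered ring as such does not bring the low number of compound 1. The bromo group shows the clearer separation: hydrogen in place of bromo on an aromatic carbon yields a 4.1-fold higher number from compound 1 to compound 4 (0.61 log units; beyond the scatter), whereas hydrogen in place of ethoxycarbonyl on an aromatic carbon yields only a 1.2-fold lower number from compound 2 to compound 4 (0.09 log units; within the scatter), so among these compounds only bromo stands apart from the unsubstituted phenyl. No measurement offered here explains why bromo and ethoxycarbonyl differ in this way.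

The compounds shown leave open whether another halogen such as chloro, or an amine, on that aromatic ring would pull the number down as bromo does, and whether a longer chain between the nitrogen and the ring would matter. They also leave open what happens on the other side of the thiourea if trifluoromethyl gives way to a group such as a carboxylic acid.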